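This account rests on a few compounds, and the source may have more. Where it says the series, first, only, none or still open, it means among the compounds named here.

Three closely related compounds have been tested in a functional assay on MCF7 cells (Homo sapiens) for inhibition, read by sulforhodamine B assay; a lower number here means a stronger inhibitor of growth, a higher number a weaker inhibitor of growth. Compound 1 `FC(F)(F)Oc1ccc(-c2ccc(-c3ccc(-c4nc5ccccc5[nH]4)cc3)cc2)cc1` gives 38400 nM. Compound 2 `Oc1ccc(-c2ccc(-c3ccc(-c4nc5ccccc5[nH]4)cc3)cc2)cc1` gives 30500 nM, and compound 3 `Cc1ccc2[nH]c(-c3ccc(-c4ccc(-c5ccc(OC(F)(F)F)cc5)cc4)cc3)nc2c1` gives 31000 nM. All three numbers sit close together, and none of the steps between them is larger than repeated measurements usually show.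

Compound 2 differs from compound 1 by hydrogen in place of trifluoromethyl on an oxygen on an aromatic ring; this change gave a 1.3-fold lower number from compound 1 to compound 2 (0.10 log units; within the scatter). Compound 3 differs from compound 1 by methyl in place of hydrogen on an aromatic carbon; this change gave a 1.2-fold lower number from compound 1 to compound 3 (0.09 log units; within the scatter).

Compound 4 `Cc1ccc2[nH]c(-c3ccc(-c4ccc(-c5ccc(O)cc5)cc4)cc3)nc2c1` has not yet been measured. It differs from compound 3 by hydrogen in place of trifluoromethyl on an oxygen on an aromatic ring, the same change as that from compound 1 to compound 2, made on the same place; the cores of the two pairs differ only by the methyl in place of hydrogen on an aromatic carbon already described. The step from compound 3 to compound 4 is expected to be small, a 1.3-fold lower number from compound 3 to compound 4 (0.11 log units; within the scatter), because the same change gave a 1.3-fold lower number from compound 1 to compound 2 (0.10 log units; within the scatter) in the first pair. Compound 4 is estimated at 24000 nM, with a likely range from 10000 nM to 55000 nM.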

Compound 4, concentration for 50% growth inhibition: 12100 nM
For compound 4 the middle estimate is 2.0-fold (0.30 log units) above the measured one, and the stated range covers the measured number.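

In this assay, replacing trifluoromethyl with hydrogen on the oxygen, on the core that carries the methyl, gave a 2.6-fold lower number from compound 3 to compound 4 (0.41 log units; beyond the scatter), and adding the methyl to the core that carries the hydroxy group gave a 2.5-fold lower number from compound 2 to compound 4 (0.40 log units; beyond the scatter). The trifluoromethoxy to hydroxy change cannot be said to act differently on the two cores, since its two steps point the same way and the gap between them stays small: the same change on two cores in this assay, a 1.3-fold lower number (0.10 log units; within the scatter) from compound 1 to compound 2 and a 2.6-fold lower number (0.41 log units; beyond the scatter) from compound 3 to compound 4, 2.0-fold (0.31 log units) apart, within the scatter of two such steps The methyl change reads the same way, yet two cores cannot prove that the steps are truly equal, nor that a change carries over to cores beyond these: the same change on two cores in this assay, a 1.2-fold lower number (0.09 log units; within the scatter) from compound 1 to compound 3 and a 2.5-fold lower number (0.40 log units; beyond the scatter) from compound 2 to compound 4, 2.0-fold (0.31 log units) apart, within the scatter of two such steps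

The compounds shown cover only hydrogen and trifluoromethyl on that oxygen, and only hydrogen and methyl on the aromatic carbon. Going by these compounds, it remains open how a methyl ether or an amine in place of the hydroxy group would behave, or how a chlorine or a longer chain would compare with the methyl.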